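The source may report more compounds than this note shows. Statements on the series, on what has been measured and on what is new or still open speak of the compounds shown alone.

Values measured in a functional assay on DU-145 cells (Homo sapiens) for inhibition, read by trypan blue exclusion, with a stated time of 96 h; a higher number here means a weaker inhibitor of growth, a lower number a stronger inhibitor of growth
- compound 1 `Cc1ccc(CS/C(=C/c2c(O)cc(O)cc2O)C(=O)c2ccc(Cl)cc2)cc1` gives 50000 nM
- compound 2 `Cc1ccc(CS/C(=C/c2cc(C)ccc2C)C(=O)c2ccc(Cl)cc2)cc1` gives 10000 nM
- compound 3 `Cc1ccc(CS/C(=C/c2ccccc2F)C(=O)c2ccc(Cl)cc2)cc1` gives 10000 nM

Compound 3 sits level with compound 2, and the two share the low end of the three numbers. The comparison between them shows no change at the digits printed from compound 2 to compound 3 (within the scatter) and the comparison with compound 1 shows a 5.0-fold lower number from compound 1 to compound 3 (0.70 log units; beyond the scatter).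

Compound 4 `CSc1ccc(/C=C(/SCc2ccc(C)cc2)C(=O)c2ccc(Cl)cc2)cc1` has not yet been measured. It carries 4-(methylsulfanyl)phenyl in place of 2-fluorophenyl on a double-bonded chain carbon bound to a double-bonded chain carbon.

All three measured steps fall at this same place. Two of them remove 2,4,6-trihydroxyphenyl, and they read a 5.0-fold lower number from compound 1 to compound 2 (0.70 log units; beyond the scatter) and a 5.0-fold lower number from compound 1 to compound 3 (0.70 log units; beyond the scatter). Compound 4 has no hydroxyl on this ring, so the nearer guide is the exchange from 2,5-dimethylphenyl to 2-fluorophenyl in compound 3 (no change at the digits printed from compound 2 to compound 3 (within the scatter)). For the measured compounds named here, no measured compound carries methylsulfanyl, so this guide is a loose one. In this assay, no step beyond the scatter is therefore expected, in either direction. The expected step is no change at the digits printed from compound 3 to compound 4 (within the scatter).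

The estimated value for compound 4 is 10000 nM, within an expected range of 3000 nM to 30000 nM.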

Compound 4, concentration for 50% growth inhibition: 25000 nM
Compound 4: the middle estimate sits 2.5-fold (0.40 log units) below what was measured; low and high end bracket the measured number.
By their numbers in this assay, from the lowest: compounds 2 and 3 (each within the scatter of the next); then compounds 4 and 1 (each within the scatter of the next).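

In this assay, the position on a double-bonded chain carbon bound to a double-bonded chain carbon no longer looks indifferent to the choice of ring among those without hydroxyl groups: 2-fluorophenyl and 2,5-dimethylphenyl had matched each other, but 4-(methylsulfanyl)phenyl separates from both (a 2.5-fold higher number from compound 3 to compound 4 (0.40 log units; beyond the scatter); a 2.5-fold higher number from compound 2 to compound 4 (0.40 log units; beyond the scatter)). The comparison with the hydroxylated ring shows that losing the hydroxyl groups does not by itself bring a compound level with compounds 2 and 3, since compound 4 cannot be told apart from the 2,4,6-trihydroxyphenyl compound (a 2.0-fold lower number from compound 1 to compound 4 (0.30 log units; within the scatter)). Nothing among the data shown gives a measured property that would account for this shift in the number.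

The compounds shown leave open whether the shift belongs to the sulfur-bearing methylsulfanyl group itself or to any group held at that place on the ring, which 4-methoxyphenyl or 2-(methylsulfanyl)phenyl would help to separate. For the compounds shown here, they also leave open how this position would respond to a ring carrying an amine or a carboxylic acid, since every number so far lies in a narrow band of weak growth inhibition.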